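Pyridyl ethers on a shared core: estimating a methylpyridyl variant

The source may hold more compounds than are shown below. What is called first, only, known or untested is meant among the compounds shown, and "the series" means these compounds.

Measured so far, in a functional assay on CHO cells for positive allosteric modulation of metabotropic glutamate receptor 2 (Homo sapiens), read by scintillation counting and GTPgammaS binding, with a stated time of 30 min; a higher number here means that more compound is needed for the effect, a lower number that less compound is needed:
- compound 1, `CC(C)CCn1ccc(-c2ccc(OCC3CC3)cc2)c(C#N)c1=O`: 290 nM
- compound 2, `CC(C)CCn1ccc(-c2ccc(Oc3ccccn3)cc2)c(C#N)c1=O`: 646 nM
- compound 3, `CC(C)CCn1ccc(-c2ccc(Oc3ccncc3)cc2)c(C#N)c1=O`: 550 nM

Compound 3 sits between the other two numbers, and both gaps are within the usual scatter: the step of a 1.9-fold higher number from compound 1 to compound 3 (0.28 log units; within the scatter) and the step of a 1.2-fold lower number from compound 2 to compound 3 (0.07 log units; within the scatter) are each too small to call a real difference. Going by the values given here, only the step of a 2.2-fold higher number from compound 1 to compound 2 (0.35 log units; beyond the scatter) just crosses the scatter, and even that is modest.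

The new compound 4, `Cc1ncccc1Oc1ccc(-c2ccn(CCC(C)C)c(=O)c2C#N)cc1`, differs from compound 3 in one place: 2-methylpyridin-3-yl in place of pyridin-4-yl on an oxygen on an aromatic ring. Among the compounds with values here, three measured steps touch this position. Two of them swap a cyclopropylmethyl for a pyridyl ring and give slightly higher numbers; the third swaps one pyridyl isomer for another and gives no change beyond the scatter. The change to compound 4 is of the third kind, a pyridyl for a pyridyl, with a methyl added. Within the data shown here, no measured step shows what such a methyl does here.

The expectation for compound 4 is therefore a number close to that of compound 3, a step of a 1.1-fold lower number from compound 3 to compound 4 (0.04 log units; within the scatter) that stays within the scatter. The estimate for compound 4 in this assay is 500 nM, with a range from 200 nM to 1300 nM.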

Compound 4, half-maximal effective concentration: 275 nM
Estimate against measurement, compound 4: 1.8-fold (0.26 log units) above; measured number inside the range.
By their numbers in this assay, from the lowest: compounds 4, 1, 3 and 2 (each within the scatter of the next, the first and the last beyond it).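

In this assay, the change to 2-methylpyridin-3-yl gives the first step showing a pyridyl ether with a lower number than another pyridyl ether beyond the scatter, a 2.3-fold lower number from compound 2 to compound 4 (0.37 log units; beyond the scatter), though that step is only modest. The other two new steps stay within the scatter, a 2.0-fold lower number from compound 3 to compound 4 (0.30 log units; within the scatter) and a 1.1-fold lower number from compound 1 to compound 4 (0.02 log units; within the scatter), so compound 4 cannot be told apart from compound 3 or compound 1, and the position therefore accepts a methylated pyridyl ring with no measurable loss against cyclopropylmethyl, whereas compound 2 stood a modest step above compound 1. Why the 2-methylpyridin-3-yl group gives this result has no support in any data available here.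

The change from compound 3 to compound 4 moves the ring attachment and adds a methyl in one step, so the compounds shown leave open which of the two matters, a question that the plain pyridin-3-yl ether could address. Also open, as far as these compounds go, is whether an ethyl, a methoxy or a chlorine on that ring would give a number like that of compound 4.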